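A few compounds are considered here, and "the series" means these few. Any claim that something is new, unique, unknown or untested is made for them only; others in the source may bear on it.

The measured compounds:
Compound 1, `Cc1ccc(-c2nc(NC(=O)c3ccccc3)c3cc(Cl)ccc3n2)cc1`, gives 16.2 ug/mL in a functional assay on HeLa cells (Homo sapiens) for antiproliferative activity, read by MTT assay, with a stated time of 48 h; on this read-out lower numbers stand for stronger inhibition and higher numbers for weaker inhibition.
Compound 2, `CSc1nc(-c2ccc(C)cc2)nc2ccc(Cl)cc12`, gives 14.7 ug/mL in this assay.
Compound 3, `Cc1ccc(-c2nc(SCc3ccccc3)c3cc(Cl)ccc3n2)cc1`, gives 11.3 ug/mL in this assay.

All three share one core and differ only in the group on one aromatic carbon. Compound 3 has the lowest of the three numbers, yet its distance to the others is small: a 1.4-fold lower number from compound 1 to compound 3 (0.16 log units; within the scatter) and a 1.3-fold lower number from compound 2 to compound 3 (0.11 log units; within the scatter), both within the scatter, so none of the three can be called stronger than another. The remaining step, a 1.1-fold lower number from compound 1 to compound 2 (0.04 log units; within the scatter), is also within the scatter.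

Compound 4, `Cc1ccc(-c2nc(SCC#N)c3cc(Cl)ccc3n2)cc1`, has not yet been measured in this assay. It differs from compound 3 in one place: cyano in place of phenyl on a saturated chain carbon bound to a sulfur. The step that bears most directly on this change is a 1.3-fold lower number from compound 2 to compound 3 (0.11 log units; within the scatter), where a phenyl entered on the same chain carbon bound to a sulfur and the number hardly moved. Three quite different groups on this aromatic carbon, benzamido, methylsulfanyl and benzylsulfanyl, gave numbers within the scatter of each other. Among the compounds with values here, no measured compound carries a cyano group, so that part of the change rests on no direct precedent. Taken together, compound 4 is expected to show no step beyond the scatter, a 1.2-fold higher number from compound 3 to compound 4 (0.06 log units; within the scatter), and its estimated value in this assay is 13 ug/mL, with a range from 6 ug/mL to 28 ug/mL.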

Compound 4, half-maximal inhibitory concentration: 3.76 ug/mL
For compound 4 the middle estimate is 3.5-fold (0.54 log units) above the measured one, and the stated range ends above it.
By their numbers in this assay, from the lowest: compound 4; then compounds 3, 2 and 1 (each within the scatter of the next).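

In this assay, within the data shown here, this position had seemed indifferent to the group it carried, but the (cyanomethyl)sulfanyl group is the first to move the number beyond the scatter, against benzylsulfanyl (a 3.0-fold lower number from compound 3 to compound 4 (0.48 log units; beyond the scatter)), methylsulfanyl (a 3.9-fold lower number from compound 2 to compound 4 (0.59 log units; beyond the scatter)) and benzamido (a 4.3-fold lower number from compound 1 to compound 4 (0.63 log units; beyond the scatter)). Losing the phenyl is not enough to give this result: compound 2 also has no phenyl on the saturated chain carbon bound to the sulfur, yet it stays within the scatter of compound 3, so the lower number of compound 4 appears only when cyano stands on that carbon. Nothing measured here explains why this change lowers the number.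

As far as these compounds go, with a single cyano compound, it remains open whether the lower number belongs to the nitrile itself or would also appear with another group on this chain carbon, such as a carboxylic acid or a primary amide. From the compounds shown here alone, it is also open whether the effect survives a longer chain, as in (2-cyanoethyl)sulfanyl, or a nitrogen in place of the sulfur, as in a (cyanomethyl)amino group.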